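The source may report more compounds than this note shows. Statements on the series, on what has been measured and on what is new or still open speak of the compounds shown alone.

Compound 1 `CNC[C@@H]1CCN(c2cc3c(cc2F)c(=O)c(C(=O)O)cn3Cc2ccc(-n3cccn3)cc2)C1`: > 200000 nM
Compound 2 `NCCNc1cc2c(cc1F)c(=O)c(C(=O)O)cn2Cc1ccc(-c2ccccc2)cc1`: 72800 nM

Both compounds were tested in an assay on isolated protein for inhibition of DNA topoisomerase 1 (Homo sapiens), with a stated time of 15 min; a lower number here means a stronger inhibitor, a higher number a weaker inhibitor. For compound 1 the result is only a limit of the assay, > 200000 nM, so no number is known for it and it stands outside the measured range; this is the limit of > 200000 nM in this assay, at which 1 of the 2 values shown sits. Compound 2 gives 72800 nM in this assay, a weak result. Compound 3 `O=C(O)c1cn(Cc2ccc(-n3cccn3)cc2)c2cc(NC[C@H]3CCNC3)c(F)cc2c1=O` has not yet been measured. It differs from compound 1 in one place: ((pyrrolidin-3-yl)methyl)amino in place of 3-((methylamino)methyl)pyrrolidin-1-yl on an aromatic carbon. No step between two measured compounds is shown, so the size of this change can only be estimated. Because compound 2 gives 72800 nM in this assay while also carrying an amino-linked side chain on the shared core, compound 3 is expected to remain a weak inhibitor, at an estimated 100000 nM in this assay, with a range from 30000 nM to 300000 nM. The expected step is an at least 2.0-fold lower number from compound 1 to compound 3 (0.30 log units; that floor lies within the scatter), which, with compound 1 at a limit, may not reach beyond the scatter.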

Compound 3, half-maximal inhibitory concentration: 187000 nM
Compound 3: the middle estimate sits 1.9-fold (0.27 log units) below what was measured; low and high end bracket the measured number.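

On this aromatic carbon, ortho to a fluoro group, replacing 3-((methylamino)methyl)pyrrolidin-1-yl with ((pyrrolidin-3-yl)methyl)amino gives, in this assay, an at least 1.0-fold lower number from compound 1 to compound 3 (0.02 log units; that floor lies within the scatter). Compound 1 stands at a limit of the assay, > 200000 nM, which is not a number. Among these compounds, this change therefore gives the first real number for this pair, and compound 3 at 187000 nM is still a weak inhibitor. The result for compound 1 remains a limit: the limit of > 200000 nM in this assay, at which 1 of the 3 values shown sits.

As far as these compounds go, the true size of the step stays unknown, and it may be no larger than the scatter or much larger. Also open, from the compounds shown here alone, is whether a piperazine ring on this aromatic carbon, or a carboxamide in place of the carboxylic acid on the shared core, would give a clearly lower number in this assay.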